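Notes on compound 4: ester in place of methylsulfonyl

The compounds below may be only part of what the source reports. "The series", "measured", "known", "first", "only" and "open" are said of these compounds alone.

Measured so far in an ADME assay on Vero cells (Chlorocebus sabaeus) for cytotoxicity, read by MTT assay, with a stated time of 48 h; a higher number here means a weaker inhibitor, a lower number a stronger inhibitor:
- compound 1, `CS(=O)(=O)OC1CCC(CN2CCN(c3cc(=O)c4cc(C(F)(F)F)cc([N+](=O)[O-])c4s3)CC2)CC1`: compound 1 gives > 64 ug/mL, a limit of the assay.
- compound 2, `CS(=O)(=O)NC1CCC(CN2CCN(c3cc(=O)c4cc(C(F)(F)F)cc([N+](=O)[O-])c4s3)CC2)CC1`: compound 2 gives 48.5 ug/mL.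
- compound 3, `O=c1cc(N2CCN(CC3CCC(OS(=O)(=O)c4ccc5ccccc5c4)CC3)CC2)sc2c([N+](=O)[O-])cc(C(F)(F)F)cc12`: compound 3 gives > 64 ug/mL, a limit of the assay.

Compound 1 stands at the limit of > 64 ug/mL in this assay, at which 2 of the 3 values shown sit, so no number is known for it, only that it sits at the limit. Compound 4, `O=C(OC1CCC(CN2CCN(c3cc(=O)c4cc(C(F)(F)F)cc([N+](=O)[O-])c4s3)CC2)CC1)c1ccc(C(F)(F)F)cc1`, differs from compound 1 in one place: (4-(trifluoromethyl)phenyl)carbonyl in place of methylsulfonyl on an oxygen on a saturated carbon.

Going by the values given here, two measured steps bear on this change. The first, an at least 1.3-fold lower number from compound 1 to compound 2 (0.12 log units; that floor lies within the scatter), alters the same attachment point and stays within the scatter. The second, a step that the two limits leave unreadable from compound 1 to compound 3, places a larger aromatic group on the sulfonyl sulfur, and both ends at the limit leave its size unreadable. Neither step gives a readable move beyond the scatter, so no step beyond the scatter is expected for compound 4, and a value at or near the limit is the likeliest outcome.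

Compound 4 is therefore estimated at 64 ug/mL, with a range from 20 ug/mL to 160 ug/mL. The expected step is a number no higher from compound 1 to compound 4 (the limit leaves the size open).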

Compound 4, half-maximal inhibitory concentration: > 64 ug/mL
Compound 4: no number, only a limit; the forecaster's own chance of this, stated with the estimate: 60%; the middle value lies on the limit itself.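

No new step can be read between compound 1 and compound 4, since each gives only a limit and not a number: the limit of > 64 ug/mL in this assay, at which 3 of the 4 values shown sit. The compounds shown leave open whether (4-(trifluoromethyl)phenyl)carbonyl in place of methylsulfonyl moves the number at all.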